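Swapping an ethynyl for a dimethylsulfamoyl-bearing chain

The compounds below may be only part of what the source reports. "The series", "measured", "known", "first", "only" and "open" are said of these compounds alone.

Two compounds sharing a common core have been examined in a functional assay on the whole organism with Rattus norvegicus as the target; on this read-out higher numbers stand for an effect only at larger amounts of compound and lower numbers for an effect already at smaller amounts. Compound 1, `Nc1nc2ccc(OC(F)(F)C(F)(F)F)cc2s1`, gives 2.5 mg/kg in this assay. Going by the values given here, compound 2, `C#CCn1c(=N)sc2cc(OC(F)(F)F)ccc21`, gives 4 mg/kg in this assay; compound 2 and compound 1 have the two numbers measured so far, and the gap between them falls within the usual scatter of repeated measurements, so the two cannot be told apart on these data.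

Compound 3, `CN(C)S(=O)(=O)CCn1c(=N)sc2cc(OC(F)(F)F)ccc21`, has not yet been measured in this assay. It differs from compound 2 in one place: (dimethylsulfamoyl)methyl in place of ethynyl on a saturated chain carbon bound to an aromatic nitrogen. The ethynyl group of compound 2 is replaced by a group with seven heavy atoms carrying two hydrogen-bond acceptors, on the same saturated chain carbon bound to the aromatic nitrogen.

Among the compounds with values here, no comparable step between measured compounds exists in this set, so the expected size of the change rests only on the general behaviour of the two measured compounds. A modest shift in this assay toward larger amounts of compound is expected, though one that may well stay within the scatter. For compound 3 the estimate in this assay is 5 mg/kg, with a range from 1.5 mg/kg to 16 mg/kg, which would mean a step of a 1.3-fold higher number from compound 2 to compound 3 (0.10 log units; within the scatter). The measured number will show whether the expectation holds.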

Compound 3, dose for half-maximal effect: > 10 mg/kg
Compound 3: a limit, no number; the forecaster's own chance of this, stated with the estimate: 10%; middle value at least 2.0-fold (0.30 log units) away from the limit.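

For compound 3, this assay gives a limit and not a number: the limit of > 10 mg/kg in this assay, at which 1 of the 3 values shown sits. Even read as a limit, replacing ethynyl with (dimethylsulfamoyl)methyl on a saturated chain carbon bound to an aromatic nitrogen gives an at least 2.5-fold higher number from compound 2 to compound 3 (0.39 log units; beyond the scatter), so the true size of the step remains unknown and only its lower bound can be read. Going by these compounds alone, the earlier compounds offered no step in one place, so this is the first sign that the group carried at this position can change the read-out, and that this particular change moves it towards larger amounts of compound.

The compounds shown leave open whether the read-out follows the sulfamoyl atoms or simply the size of the entering group, since this single step changes both together; a plain propyl group, a longer carbon chain, an amine or a carboxylic acid on the same saturated chain carbon would help separate the two. They also leave open how far compound 3 lies beyond its limit, and whether any group at this position could give a lower number than ethynyl does.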